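Hydroxycarbamoyl chain shortening from compound 1 to compound 3

A few compounds are considered here, and "the series" means these few. Any claim that something is new, unique, unknown or untested is made for them only; others in the source may bear on it.

In a functional assay on Lewis lung carcinoma cells for antiproliferative activity against Lewis lung carcinoma cell line (Mus musculus), read by CCK-8 assay, with a stated time of 48 h (on this read-out lower numbers stand for stronger inhibition and higher numbers for weaker inhibition), compound 1 (`O=C(CCCCC(=O)NCCNc1nonc1/C(=N/O)Nc1ccc(F)c(Br)c1)NO`) gives > 100000 nM as a limit of the assay, not a number. Compound 2 (`Nc1ccccc1NC(=O)c1ccc(C(=O)NCCNc2nonc2/C(=N/O)Nc2ccc(F)c(Br)c2)s1`) gives 18300 nM as a measured value. Compound 3 (`O=C(CCCC(=O)NCCNc1nonc1/C(=N/O)Nc1ccc(F)c(Br)c1)NO`) carries hydroxycarbamoyl in place of (hydroxycarbamoyl)methyl on a saturated chain carbon, three bonds along the chain from a carbonyl carbon. Among the compounds with values here, no measured step covers this change, and none beyond the scatter is expected in this assay for it. The estimated step is a number no higher from compound 1 to compound 3 (the limit leaves the size open) in this expectation. In this assay compound 3 is expected at 100000 nM with 30000 nM to 300000 nM as its estimated range.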

Compound 3, half-maximal inhibitory concentration: > 100000 nM
Compound 3: no number, only a limit (the forecaster's own chance of this, stated with the estimate: 60%); the middle value sits exactly at the limit.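

Compound 1 and compound 3 both end at a limit in this assay, so no step between them can be read: the limit of > 100000 nM in this assay, at which 2 of the 3 values shown sit.

The compounds shown leave open whether the 4-(hydroxycarbamoyl)butyl and 3-(hydroxycarbamoyl)propyl chains differ at all in antiproliferative activity.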